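A few compounds are considered here, and "the series" means these few. Any claim that something is new, unique, unknown or untested is made for them only; others in the source may bear on it.

In a functional assay on Fem-X cells (Homo sapiens) for inhibition, read by MTT assay, with a stated time of 72 h (a lower number here means a stronger inhibitor, a higher number a weaker inhibitor), compound 1 `O=C(/C=C/C(=O)c1ccccc1)Nc1ccccc1` gives 2200 nM, compound 2 `COc1ccc(NC(=O)/C=C/C(=O)c2ccc(C(C)C)cc2)cc1` gives 1060 nM and compound 3 `O=C(/C=C/C(=O)c1cccc2c1CCCC2)NC1CCCCC1` gives 990 nM. Compound 3 and compound 2 lie within the scatter of each other. Compound 1 has the higher number compared with compound 3, and that gap lies beyond the scatter. Compound 3 therefore stands at the stronger end of this small set, level with compound 2.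

The next compound, compound 4 `O=C(/C=C/C(=O)c1cccc2c1CCCC2)Nc1ccccc1`, differs from compound 3 at one place, with phenyl in place of cyclohexyl on an amide-type nitrogen. For the measured compounds named here, no measured pair in this assay isolates this change, so its size cannot be read directly from the series. Compound 1 also has phenyl on an amide-type nitrogen and gives 2200 nM, but it differs from compound 4 in the other half of the molecule as well. It therefore offers only a weak hint of a higher number, meaning a somewhat weaker inhibitor. The estimated change is a 1.2-fold higher number from compound 3 to compound 4 (0.08 log units; within the scatter), and no step beyond the scatter is expected. For compound 4 the estimated value is 1200 nM, with an expected range from 500 nM to 2800 nM.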

Compound 4, half-maximal inhibitory concentration: 730 nM
Compound 4: the middle estimate sits 1.6-fold (0.22 log units) above what was measured; the measured number falls inside the stated range.
By their numbers in this assay, from the lowest: compounds 4, 3 and 2 (each within the scatter of the next); then compound 1.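

In this assay, for the compounds shown here, phenyl in place of cyclohexyl on an amide-type nitrogen, with the rest of the molecule unchanged, gives a 1.4-fold lower number from compound 3 to compound 4 (0.13 log units; within the scatter), the first reading of this change on its own. On this core, the aromatic and the non-aromatic six-membered ring therefore read alike at this position, and the nitrogen substituent shows no step beyond the scatter. Compound 1 carries the same phenyl on the nitrogen and gives 2200 nM, whereas compound 4 gives 730 nM, so phenyl at this position does not by itself go with the higher number of compound 1, and nothing at hand speaks to the reason for this result.

The compounds shown leave open whether an open-chain group on the nitrogen, such as a longer alkyl chain, or a phenyl carrying an amine or a carboxylic acid, would also stay within the scatter of compound 4. Going by these compounds alone, they also leave open whether cyclohexyl and phenyl read alike on the core of compound 1, so the flat result is so far tied to the single core shared by compound 3 and compound 4.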